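A few compounds are considered here, and "the series" means these few. Any claim that something is new, unique, unknown or untested is made for them only; others in the source may bear on it.

Compound 3 `Cc1cc(Br)ccc1NC(=O)CN1CCC(c2cccc[n+]2[O-])CC1`, which carries the 4-bromo-2-methylphenyl group, stands second highest of the three numbers seen so far in a functional assay on HEK293 cells for agonist activity at D(4) dopamine receptor (Homo sapiens), read by FLIPR; a lower number here means a smaller maximal response, a higher number a larger maximal response: compound 3 reaches 61%. Within the data shown here, compound 2 `O=C(CN1CCC(c2cccc[n+]2[O-])CC1)Nc1cccc(Cl)c1Cl` reaches 66%, and the only step measured between neighbours, a number 5 percentage points lower from compound 2 to compound 3 (within the scatter), lies within the scatter. Compound 1 `CC(C)Oc1cccc(NC(=O)CN2CCC(c3cccc[n+]3[O-])CC2)c1` gives the lowest number, 48%. Compound 4 `O=C(CN1CCC(c2cccc[n+]2[O-])CC1)Nc1cccc(Cl)c1` differs from compound 3 by 3-chlorophenyl in place of 4-bromo-2-methylphenyl on an amide-type nitrogen. Among the measured compounds shown here, no measured step covers this change; compound 2 also carries chlorine on that ring and sits close to compound 3, while compound 1 sits lower. The expected step from compound 3 to compound 4 is therefore small, a number 3 percentage points lower from compound 3 to compound 4 (within the scatter). Compound 4 is estimated to reach 58%, likely between 45% and 70%.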

Compound 4, largest response reached (reported as efficacy), in percent of the reference or control that the assay uses: 76%
The estimate for compound 4 lay 18 percentage points below the measured number, outside the stated range (above it).
By their numbers in this assay, from the lowest: compound 1; then compounds 3, 2 and 4 (each within the scatter of the next, the first and the last beyond it).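

In this assay, 3-chlorophenyl in place of 4-bromo-2-methylphenyl on the amide-type nitrogen gives (a number 15 percentage points higher from compound 3 to compound 4 (beyond the scatter)), and chloro in place of isopropoxy on an aromatic carbon gives (a number 28 percentage points higher from compound 1 to compound 4 (beyond the scatter)), so changes to this group can shift the maximal response beyond the scatter. Hydrogen in place of chloro on an aromatic carbon gives (a number 10 percentage points higher from compound 2 to compound 4 (within the scatter)), a change that cannot be told apart from the scatter. The compounds shown leave open how an amine or a carboxylic acid on this phenyl ring would compare. No supporting measurement accounts for these steps.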